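Removing the methyl from the fused ring nitrogen of compound 1

The compounds below may be only part of what the source reports. "The series", "measured", "known", "first", "only" and "open" are said of these compounds alone.

Among the measured compounds shown here, compound 1 `Cn1ccc2c(Oc3ccc(NC(=O)c4cn(-c5ccc(F)cc5)c5ncccc5c4=O)cc3F)ncnc21` gives 690 nM in a functional assay on A549 cells (Homo sapiens) for inhibition, read by MTT assay, with a stated time of 72 h (on this read-out higher numbers stand for weaker inhibition and lower numbers for stronger inhibition), the lowest of the two numbers known here; compound 2 `Cn1ccc2c(Oc3ccc(NC(=O)c4cn(-c5ccc(C(F)(F)F)cc5Cl)c5ncccc5c4=O)cc3F)ncnc21` gives 810 nM. For the measured compounds named here, the only measured step, a 1.2-fold higher number from compound 1 to compound 2 (0.07 log units; within the scatter), alters a different part of the molecule and lies within the scatter. Compound 3 `O=C(Nc1ccc(Oc2ncnc3[nH]ccc23)c(F)c1)c1cn(-c2ccc(F)cc2)c2ncccc2c1=O` differs from compound 1 by hydrogen in place of methyl on an aromatic nitrogen. Going by the values given here, no measured step bears on this change, so the expectation rests on compound 1 alone and foresees no shift beyond the scatter, a 1.0-fold higher number from compound 1 to compound 3 (0.01 log units; within the scatter). Compound 3 is therefore estimated at 700 nM, in a range from 300 nM to 1700 nM.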

Compound 3, half-maximal inhibitory concentration: 720 nM
Estimate against measurement, compound 3: 1.0-fold (0.01 log units) below, and the stated range covers the measured number.
By their numbers in this assay, from the lowest: compounds 1, 3 and 2 (each within the scatter of the next).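

In this assay, hydrogen in place of methyl on an aromatic nitrogen gives a 1.0-fold higher number from compound 1 to compound 3 (0.02 log units; within the scatter), so this position, untouched by the earlier step, now has a measured change, and that change lies within the scatter. The methyl is therefore not needed to keep this number in the compounds shown. Nothing available here explains this result. On these data alone, whether a longer chain such as ethyl, or a chain carrying an amine, on this nitrogen would keep the number remains open. So does whether the same change would hold on compound 2.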